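Swapping the urea aryl group in a diaryl urea series

The source may report more compounds than this note shows. Statements on the series, on what has been measured and on what is new or still open speak of the compounds shown alone.

Compound 1 `CN(C)CCn1cnnc1-c1cc(Oc2ccc(NC(=O)Nc3ccc(Cl)c(C(F)(F)F)c3)cc2F)ccn1` and compound 2 `CCN(CC)CCn1cnnc1-c1cc(Oc2ccc(NC(=O)Nc3ccc(Cl)c(C(F)(F)F)c3)cc2F)ccn1` share one core. In a functional assay on MDA-MB-231 cells (Homo sapiens) for antiproliferative activity, read by MTT assay, with a stated time of 72 h (on this read-out higher numbers stand for weaker inhibition and lower numbers for stronger inhibition), compound 1 gives 1070 nM, and compound 2 gives 1540 nM. The step of a 1.4-fold higher number from compound 1 to compound 2 (0.16 log units; within the scatter) is within the scatter, so compound 2 stands at the higher of two numbers that cannot be told apart. Compound 3 `CCN(CC)CCn1cnnc1-c1cc(Oc2ccc(NC(=O)Nc3ccc(Cl)cc3Cl)cc2F)ccn1` carries 2,4-dichlorophenyl in place of 4-chloro-3-(trifluoromethyl)phenyl on an amide-type nitrogen. Going by the values given here, no measured step touches this part of the molecule, so the change from compound 2 to compound 3 has no precedent here. Compound 3 is therefore expected to give 2500 nM, in a wide range from 800 nM to 8000 nM, a step of a 1.6-fold higher number from compound 2 to compound 3 (0.21 log units; within the scatter).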

Compound 3, half-maximal inhibitory concentration: 1790 nM
The estimate for compound 3 lay 1.4-fold (0.15 log units) above the measured number, and the stated range covers the measured number.
By their numbers in this assay, from the lowest: compounds 1, 2 and 3 (each within the scatter of the next).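

The first change shown at the urea aryl group, 2,4-dichlorophenyl in place of 4-chloro-3-(trifluoromethyl)phenyl on an amide-type nitrogen, gives a 1.2-fold higher number from compound 2 to compound 3 (0.07 log units; within the scatter) in this assay. In this single pair, the aryl group can therefore go from 11 heavy atoms to 8 without the number leaving the scatter. No measurement here bears on why. As far as these compounds go, it remains open whether a phenyl group carrying a nitrile, an amine or a carboxylic acid would also stay within the scatter. From the compounds shown here alone, it is equally open whether the 2,4-dichlorophenyl group would behave alike on the dimethylamino compound 1.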